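The compounds below may be only part of what the source reports. "The series", "measured", "known", "first", "only" and "open" are said of these compounds alone.

Measured so far in an ADME assay on the whole organism for pharmacokinetics, with Rattus norvegicus as the target, read by LC-MS, at a dose of 10 mg/kg by the oral route; a lower number here means less compound in the circulation, a higher number more compound in the circulation at the dose given:
- compound 1, `COc1ccc2c(c1)C(=O)N(C[C@@]1(c3cc4ncccc4o3)NC(=O)N(COC(=O)C(C)(C)C)C1=O)C2`: 6640 ng.h/mL
- compound 2, `COc1ccc2c(c1)C(=O)N(C[C@@]1(c3cc4ncccc4o3)NC(=O)N(C(C)C)C1=O)C2`: 174 ng.h/mL

Compound 2 gives the lowest of the two numbers recorded in this assay; its nearest neighbour is compound 1, and the step of a 38-fold lower number from compound 1 to compound 2 (1.58 log units; beyond the scatter) separates them. That step is the only one measured in the series, and it sits at the same ring nitrogen that is varied again in compound 3, `COCCOCCOCCN1C(=O)N[C@@](CN2Cc3ccc(OC)cc3C2=O)(c2cc3ncccc3o2)C1=O`. The change from compound 2 to compound 3 is 2-(2-(2-methoxyethoxy)ethoxy)ethyl in place of isopropyl on an amide-type nitrogen in a ring.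

Among the compounds with values here, no measured pair carries a 2-(2-(2-methoxyethoxy)ethoxy)ethyl group, so the expectation rests on the single step of a 38-fold lower number from compound 1 to compound 2 (1.58 log units; beyond the scatter), which shows that exchanging the group on this amide-type nitrogen can shift this assay by a large amount. The direction for compound 3 is not fixed by the data; the chain differs from both the isopropyl of compound 2 and the (((tert-butyl)carbonyl)oxy)methyl of compound 1. A step of moderate size upward from compound 2 is expected, with wide uncertainty: the estimated change is a 2.0-fold higher number from compound 2 to compound 3 (0.30 log units; within the scatter).

For compound 3 the expected value in this assay is 350 ng.h/mL, within a range of 60 ng.h/mL to 2000 ng.h/mL.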

Compound 3, area under the concentration-time curve: 10.8 ng.h/mL
Estimate against measurement, compound 3: 32-fold (1.51 log units) above; measured number outside the range, below it.
By their numbers in this assay, from the lowest: compound 3; then compound 2; then compound 1.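

At the amide-type nitrogen in a ring, the group can pull the number in this assay well under the isopropyl level: the step of a 16-fold lower number from compound 2 to compound 3 (1.21 log units; beyond the scatter) is large and runs opposite to the rise expected for 2-(2-(2-methoxyethoxy)ethoxy)ethyl. The earlier pair showed only that this position responds strongly, whereas the three groups now give a clear order, with isopropyl in the middle and all steps beyond the scatter. Oxygen atoms in the group do not by themselves set the level, since both end members carry them and the step of a 610-fold lower number from compound 1 to compound 3 (2.79 log units; beyond the scatter) spans the whole series; nothing at hand bears on the cause of these differences.

Open, as far as these compounds go, is how a shorter chain such as 2-methoxyethyl, or a chain ending in an amine or a carboxylic acid, would sit in this order at the same nitrogen, and whether the amide hydrogen alone there would fall nearer compound 2 or compound 3. Also open, from the compounds shown here alone, is whether the order of the three groups holds at another dose or by another route.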